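Oxazolyl amide on the shared core: an expected efficacy

The compounds below may be only part of what the source reports. "The series", "measured", "known", "first", "only" and "open" are said of these compounds alone.

Measured in a functional assay (Sus scrofa) with sulfonylurea receptors; K-ATP channels (Homo sapiens) as the target; a higher number here means a larger maximal response, a lower number a smaller maximal response:
compound 1, `CC(C)=CC(=O)Nc1c(C(O)(C(F)(F)F)C(F)(F)F)ccc2ccccc12`: 96%
compound 2, `COCC(=O)Nc1c(C(O)(C(F)(F)F)C(F)(F)F)ccc2ccccc12`: 93%
compound 3, `Cc1cccc(C(=O)Nc2c(C(O)(C(F)(F)F)C(F)(F)F)ccc3ccccc23)c1`: 97%

The three numbers sit close together. Compound 1 is separated from compound 3 by a number 1 percentage points higher from compound 1 to compound 3 (within the scatter) and from compound 2 by a number 3 percentage points lower from compound 1 to compound 2 (within the scatter); the remaining pair shows a number 4 percentage points higher from compound 2 to compound 3 (within the scatter). Every exchange on the carbonyl carbon so far, whether a chain or a ring enters, has left the maximal response unchanged beyond the scatter.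

Compound 4, `O=C(Nc1c(C(O)(C(F)(F)F)C(F)(F)F)ccc2ccccc12)c1cnco1`, carries the change (1,3-oxazol-5-yl in place of 2-methylprop-1-en-1-yl on a carbonyl carbon). The two measured steps from compound 1, each within the scatter, bear on it, and no step beyond the scatter is therefore expected in this assay: the expected step is a number 1 percentage points lower from compound 1 to compound 4 (within the scatter). Compound 4 is estimated at 95%, within 85% to 103%.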

Compound 4, largest response reached (reported as efficacy), in percent of the reference or control that the assay uses: 97%
Compound 4: the middle estimate sits 2 percentage points below what was measured; the measured number falls inside the stated range.
By their numbers in this assay, from the lowest: compounds 2, 1, 3 and 4 (each within the scatter of the next).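

In this assay, the 1,3-oxazol-5-yl group, the only ring with hetero atoms among the four groups on this carbonyl carbon, keeps the response within the scatter of all three others: a number 1 percentage points higher from compound 1 to compound 4 (within the scatter), no change at the digits printed from compound 3 to compound 4 (within the scatter), and a number 4 percentage points higher from compound 2 to compound 4 (within the scatter). Two hydrogen-bond acceptors enter where the 2-methylprop-1-en-1-yl group has none, and no step beyond the scatter follows. Nothing available here offers an explanation for this result. The compounds shown leave open whether any group at this place can move the maximal response beyond the scatter, for instance an amine, a carboxylic acid or a longer chain.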